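The compounds below may be only part of what the source reports. "The series", "measured", "known", "first", "only" and "open" are said of these compounds alone.

Compound 1 `N=C(S)CCCn1nc(-c2ccccc2)ccc1=O` gives 75.6% in a functional assay on the whole organism (stomach) for inhibition, with Rattus norvegicus as the target, at a dose of 100 mg/kg by the intraduodenal route; on this read-out higher numbers stand for more inhibition at the one dose given (going by the name of the read-out) and lower numbers for less inhibition.
Compound 2 `CNC(=O)CCn1nc(-c2ccccc2)ccc1=O` gives 3.5% in this assay.
Compound 3 `N=C(S)CCn1nc(-c2ccccc2)ccc1=O` gives 53.7% in this assay.

Compound 3 stands second highest of the three: the step of a number 21.9 percentage points lower from compound 1 to compound 3 (beyond the scatter) leaves it below the top value, while the step of a number 50.2 percentage points higher from compound 2 to compound 3 (beyond the scatter) sets it far above the lowest. Compound 4 `CN(C)C(=S)CCn1nc(-c2ccccc2)ccc1=O` is the next step from compound 3, with the change (a group of 5 heavy atoms (3 carbon, 1 nitrogen, 1 sulfur; no ring) in place of a group of 3 heavy atoms (1 carbon, 1 nitrogen, 1 sulfur; no ring), on a saturated chain carbon, two bonds along the chain from an aromatic nitrogen). The two largest measured steps, a number 72.1 percentage points lower from compound 1 to compound 2 (beyond the scatter) and a number 50.2 percentage points higher from compound 2 to compound 3 (beyond the scatter), both involve swapping the sulfur-bearing group for an oxygen-bearing one, and both are large. Among the measured compounds shown here, compound 4 keeps the sulfur, so those steps do not apply directly; no measured step tests the loss of the hydrogen-bond donors on its own. In this assay a modest fall from compound 3 seems the fairest expectation, with wide uncertainty. Compound 4 is therefore estimated at 35%, with a range from 5% to 65%. That estimate amounts to an expected step of a number 18.7 percentage points lower from compound 3 to compound 4 (beyond the scatter).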

Compound 4, a percentage reported as inhibition, in the whole organism at one dose (the size of the read-out at that dose, not a potency): 46%
Estimate against measurement, compound 4: 11 percentage points below; measured number inside the range.
By their numbers in this assay, from the lowest: compound 2; then compounds 4 and 3 (each within the scatter of the next); then compound 1.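

In this assay the group on compound 3 with its 2 hydrogen-bond donors can give way to a group with 0 hydrogen-bond donors at little cost, a change of a number 7.7 percentage points lower from compound 3 to compound 4 (within the scatter), so at this position those donors are not required for this level of inhibition. The sulfur-bearing group without donors also stands well clear of the oxygen-bearing group, a step of a number 42.5 percentage points higher from compound 2 to compound 4 (beyond the scatter), so that gap does not depend on those donors. It still falls short of the group of 4 heavy atoms, with a number 29.6 percentage points lower from compound 1 to compound 4 (beyond the scatter), and that group remains the highest of the set.

Nothing available explains why these groups differ. Also open, as far as these compounds go, is whether an amine or a carboxylic acid in this place, or the group of 5 heavy atoms on a longer chain, would hold this inhibition.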